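Ester in place of amide on the shared core

The compounds below may be only part of what the source reports. "The series", "measured", "known", "first", "only" and "open" are said of these compounds alone.

Working notes on the series at an assay on membranes from CHO cells for displacement of a labelled ligand from adenosine receptor A1 (Homo sapiens), read by scintillation counting, with a stated time of 60 min, tested at 1 uM; on this read-out lower numbers stand for less inhibition and higher numbers for more inhibition at the one concentration tested (going by the name of the read-out).

Compound 1 `CC1=C(C(=O)NC(C)C)C(c2ccco2)NC(=O)N1` gives 3% in this assay. Compound 2 `CC1=C(C(=O)NC(C)C)C(c2ccoc2)NC(=O)N1` gives 1%, and compound 3 `CC1=C(C(=O)NC(C)C)C(c2cccs2)NC(=O)N1` gives 2%. Compound 2 holds the lowest of the three numbers, yet every step to a neighbour stays within the scatter: a number 2 percentage points lower from compound 1 to compound 2 (within the scatter), a number 1 percentage points higher from compound 2 to compound 3 (within the scatter), and between the other two a number 1 percentage points lower from compound 1 to compound 3 (within the scatter). Each of these measured steps exchanges furan-2-yl, furan-3-yl or thiophen-2-yl for another of these groups on a saturated ring carbon; none touches the carbonyl substituent.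

Compound 4 `CC1=C(C(=O)OCC2CC2)C(c2ccoc2)NC(=O)N1` is not yet measured. Its change from compound 2 is cyclopropylmethoxy in place of isopropylamino on a carbonyl carbon. For the measured compounds named here, no measured step bears on this change, so the only guide is the level of the three values, which lie close together and low. The expected step is therefore a number 2 percentage points higher from compound 2 to compound 4 (within the scatter), nothing beyond the scatter. For compound 4 the estimate in this assay is 3%, with a range from -8% to 14%.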

Compound 4, a percentage reported as inhibition, at one concentration (the size of the read-out at that concentration, not a potency): 29%
Compound 4: middle estimate off by 26 percentage points, on the low side; the measured number lies above the stated range.
By their numbers in this assay, from the lowest: compounds 2, 3 and 1 (each within the scatter of the next); then compound 4.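

For the compounds shown here, the carbonyl substituent, which no earlier step touched, is the first place where a change moves the number in this assay beyond the scatter: with cyclopropylmethoxy in place of isopropylamino on a carbonyl carbon, the step is a number 28 percentage points higher from compound 2 to compound 4 (beyond the scatter). This single step exchanges the amide nitrogen with its hydrogen for an ester oxygen and also brings in a three-membered carbon ring, so it does not separate these changes from one another. No measurement at hand accounts for the rise.

Still open, on these data alone, is whether the ester oxygen or the cyclopropyl ring carries the step, which an isopropyl ester and a cyclopropylmethylamide on the shared core would separate. Also open, as far as these compounds go, is whether the step holds with furan-2-yl or thiophen-2-yl in place of furan-3-yl.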